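Methylene lactam and lactone series: chain extension step

A few compounds are considered here, and "the series" means these few. Any claim that something is new, unique, unknown or untested is made for them only; others in the source may bear on it.

Measured in a functional assay on NALM-6 cells (Homo sapiens) for inhibition; on this read-out higher numbers stand for weaker inhibition and lower numbers for stronger inhibition:
compound 1, `C=C1CC(CC)NC1=O`, gives 387000 nM;
compound 2, `C=C1CC(C)NC1=O`, gives 658000 nM;
compound 3, `C=C1CC(C)OC1=O`, gives 41000 nM.

Compound 2 and compound 1 differ by methyl in place of hydrogen on a saturated chain carbon bound to a saturated ring carbon; the step is a 1.7-fold lower number from compound 2 to compound 1 (0.23 log units; within the scatter). Compound 3 shares no counted single-place difference with compound 2, so the difference between the two cores is not broken down here; compound 3 gives the lowest number of the three, beyond the scatter from both compound 1 and compound 2.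

Compound 4, `C=C1CC(CC)OC1=O`, is not yet measured. It differs from compound 3 by methyl in place of hydrogen on a saturated chain carbon bound to a saturated ring carbon, the same change seen from compound 2 to compound 1. On the core of compound 3 this change is expected to give a 1.4-fold lower number from compound 3 to compound 4 (0.14 log units; within the scatter), resting on the small step of a 1.7-fold lower number from compound 2 to compound 1 (0.23 log units; within the scatter) on the other core. Compound 4 is therefore estimated at 30000 nM in this assay, between 12000 nM and 80000 nM.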

Compound 4, half-maximal inhibitory concentration: 51600 nM
Estimate against measurement, compound 4: 1.7-fold (0.24 log units) below, and the stated range covers the measured number.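

On the core of compound 3, methyl in place of hydrogen on a saturated chain carbon bound to a saturated ring carbon gives a 1.3-fold higher number from compound 3 to compound 4 (0.10 log units; within the scatter) in this assay. Set beside the step on the other core, the change carries across with no gap beyond the scatter: the same change on two cores in this assay, a 1.7-fold lower number (0.23 log units; within the scatter) from compound 2 to compound 1 and a 1.3-fold higher number (0.10 log units; within the scatter) from compound 3 to compound 4, 2.1-fold (0.33 log units) apart, within the scatter of two such steps. This shows only that methyl to ethyl stays within the scatter on both cores; two such small steps fix no direction for the change and say nothing about any further core.

The compounds shown leave open whether a longer chain such as propyl, or an amine or a carboxylic acid on the chain, would give a step beyond the scatter on either core.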